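A few compounds are considered here, and "the series" means these few. Any claim that something is new, unique, unknown or untested is made for them only; others in the source may bear on it.

Measured compounds and their numbers in an ADME assay on Caco-2 cells (Homo sapiens) for permeability, in the apical to basolateral direction; a lower number here means that the compound crosses the layer more slowly, a higher number that the compound crosses the layer faster:
compound 1, `Cn1cncc1CN1CC(N(CC2CCN(C(=O)Nc3ccc(Br)cc3)CC2)S(=O)(=O)c2ccccn2)Cc2cc(C#N)ccc21`, gives 0.6 10^-6 cm/s
compound 2, `Cn1cncc1CN1CC(N(CC2CCN(C(=O)NC(C)(C)C)CC2)S(=O)(=O)c2ccccn2)Cc2cc(C#N)ccc21`, gives 0.6 10^-6 cm/s
compound 3, `Cn1cncc1CN1CC(N(CC2CCN(C(=O)C(C)(C)C)CC2)S(=O)(=O)c2ccccn2)Cc2cc(C#N)ccc21`, gives 0.5 10^-6 cm/s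

Compound 3 stands within the scatter of both other compounds: a 1.2-fold lower number from compound 1 to compound 3 (0.08 log units; within the scatter) and a 1.2-fold lower number from compound 2 to compound 3 (0.08 log units; within the scatter). The remaining comparison, no change at the digits printed from compound 1 to compound 2 (within the scatter), is equally flat. All three share one core and differ only in the group carried on the carbonyl carbon attached to the ring amide-type nitrogen; none of those exchanges has moved the number in this assay.

Compound 4, `Cn1cncc1CN1CC(N(CC2CCN(C(=O)CC(C)(C)C)CC2)S(=O)(=O)c2ccccn2)Cc2cc(C#N)ccc21`, is the next member. Its difference from compound 3 is neopentyl in place of tert-butyl on a carbonyl carbon. The measured steps that bear on this are the two that also change the group on the same carbonyl carbon, a 1.2-fold lower number from compound 1 to compound 3 (0.08 log units; within the scatter) and a 1.2-fold lower number from compound 2 to compound 3 (0.08 log units; within the scatter), both within the scatter; the third step, no change at the digits printed from compound 1 to compound 2 (within the scatter), is also within the scatter. For the measured compounds named here, no measured step exchanges one alkyl group for a one-carbon-longer alkyl group, so the expectation rests on the flatness of the series as a whole. The step is therefore expected to stay within the scatter, no change at the digits printed from compound 3 to compound 4 (within the scatter). For compound 4 the expected value in this assay is 0.5 10^-6 cm/s, with a range from 0.25 10^-6 cm/s to 1 10^-6 cm/s.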

Compound 4, apparent permeability: 0.5 10^-6 cm/s
Estimate against measurement, compound 4: no gap at the digits printed, within the range that was stated.
By their numbers in this assay, from the lowest: compounds 3, 4, 1 and 2 (each within the scatter of the next).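

Placing neopentyl on the carbonyl carbon in place of tert-butyl gives no change at the digits printed from compound 3 to compound 4 (within the scatter) in this assay, so this is the first step in the series that extends the alkyl group on that carbon, and it leaves the number flat. The new compound also stays within the scatter of the two compounds carrying an amino-linked group at this place, with a 1.2-fold lower number from compound 2 to compound 4 (0.08 log units; within the scatter) and a 1.2-fold lower number from compound 1 to compound 4 (0.08 log units; within the scatter), so across compounds 1 to 4 neither the exchange of an amino-linked group for a carbon-linked one nor the added carbon separates the numbers. No accompanying data offer an explanation for this flatness.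

The compounds shown leave open whether the number would respond at this carbonyl carbon to a carboxylic acid, a primary amine or a hydroxyl group carried on a longer chain, since the groups here are limited to tert-butyl, neopentyl, (tert-butyl)amino and (4-bromophenyl)amino. They also leave open whether a change elsewhere on the shared core would move the number in this assay, as all four compounds carry that core unchanged.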